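This account rests on a few compounds, and the source may have more. Where it says the series, first, only, none or still open, it means among the compounds named here.

Measured so far in a functional assay on HEK293 cells for agonist activity at Toll-like receptor 8 (Homo sapiens), read by reporter gene assay; a lower number here means that less compound is needed, a higher number that more compound is needed for the effect:
- compound 1 `Cc1ncc(CO)c2c(Nc3cnccn3)c(NC(C)(C)C)oc12`: "not active" (no number reported)
- compound 2 `Cc1ncc(CO)c2c(Nc3ccccn3)c(NC(C)(C)C)oc12`: "not active" (no number reported)
- compound 3 `CCCCNc1oc2c(C)ncc(CO)c2c1Nc1ccccn1`: 9380 nM

Compound 1 stands without a number; in this assay compound 1 is reported as "not active" (no number reported), as is compound 2, and the only half-maximal effective concentration given in the set belongs to compound 3, which in this assay gives 9380 nM. For the measured compounds named here, no step between measured compounds is available, so the size of the move from compound 1 to compound 4 cannot be set from data.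

Compound 4 `Cc1ncc(CO)c2c(Nc3cnccn3)c(NC3CCCCC3)oc12` carries the change (cyclohexyl in place of tert-butyl on a nitrogen on an aromatic ring). With compound 1 lacking a number, no direction can be read off; the expectation is that compound 4 comes out weak, possibly again without a number, and if a number appears it is expected near that of compound 3.

Compound 4 is estimated at 10000 nM in this assay, expected between 2000 nM and 50000 nM.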

Compound 4, half-maximal effective concentration: 10600 nM
Compound 4: the middle estimate sits 1.1-fold (0.03 log units) below what was measured; low and high end bracket the measured number.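

In this assay, for the compounds shown here, compound 1 has no number, so no step from compound 1 to compound 4 can be read. The compounds shown leave open how far cyclohexyl in place of tert-butyl moves the half-maximal effective concentration. No evidence bears on this result.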